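This account rests on a few compounds, and the source may have more. Where it says the series, first, only, none or still open, it means among the compounds named here.

Measured so far in a functional assay on cells (Ovarian cancer cell line, Homo sapiens) for inhibition; on this read-out lower numbers stand for stronger inhibition of growth and higher numbers for weaker inhibition of growth:

- compound 1 `COc1ccc(/C=C2\CN(C)Cc3c2nc(O)c(C#N)c3-c2ccc(OC)cc2)cc1`: > 100000 nM, a limit and not a number
- compound 2 `CN1C/C(=C\c2cccs2)C2=NN(C)C(c3cccs3)C2C1`: > 100000 nM, a limit and not a number
- compound 3 `Cc1ccc(/C=C2\CN(C)CC3=C2OC(N)=C(C#N)C3c2ccc(C)cc2)cc1`: 55700 nM

Compound 2 has no exact value, only the limit > 100000 nM. It is not alone there, as the set shows (the limit of > 100000 nM in this assay, at which 2 of the 3 values shown sit). Only compound 3 gives a true number, 55700 nM.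

Compound 4 `CN1C/C(=C\c2cccs2)C2=NN(c3ccccc3)C(c3cccs3)C2C1` changes compound 2 in one place: phenyl in place of methyl on an amine nitrogen in a ring. Among the compounds with values here, no two measured compounds differ in only one place, so the data give no direct guide to the size of this change in this assay.

The value of compound 3, 55700 nM, suggests that a measurable number is possible in this set, so a modest move toward stronger inhibition is expected. The expected change is an at least 1.6-fold lower number from compound 2 to compound 4 (0.22 log units; that floor lies within the scatter), and another limit would be no surprise. For compound 4 the estimate is 60000 nM, within an expected range of 20000 nM to 100000 nM.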

Compound 4, concentration for total growth inhibition: > 100000 nM
Compound 4: only a limit was reported; the forecaster's own chance of this, stated with the estimate: 50%; middle value at least 1.6-fold (0.22 log units) from the limit.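

Within the data shown here, compound 2 and compound 4 each carry only a limit and not a number, so no step between them can be read: the limit of > 100000 nM in this assay, at which 3 of the 4 values shown sit. As far as these compounds go, whether phenyl in place of methyl on an amine nitrogen in a ring changes the result in this assay, and in which direction, stays open.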